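The source may hold more compounds than are shown below. What is called first, only, known or untested is meant among the compounds shown, and "the series" means these compounds.

Working notes on the series. For the measured compounds named here, compound 3 `CCN(CC)CCCNc1nc(-c2ccc(NC(=O)Nc3ccccc3F)cc2)nc2ccsc12` gives 860 nM in a functional assay on MDA-MB-231 cells (Homo sapiens) for cytotoxicity, read by MTT assay, with a stated time of 72 h (a lower number here means a stronger inhibitor, a higher number a weaker inhibitor), and stands second highest of the three numbers measured so far. The other two members share its core: compound 1 `CCN(CC)CCCNc1nc(-c2ccc(NC(=O)Nc3ccccc3)cc2)nc2ccsc12` gives 1230 nM in this assay, and compound 2 `CCN(CC)CCCNc1nc(-c2ccc(NC(=O)Nc3ccc(F)cc3)cc2)nc2ccsc12` gives 530 nM. Between compound 3 and its neighbours the steps are small: a 1.6-fold higher number from compound 2 to compound 3 (0.21 log units; within the scatter), and compound 1 sits within the scatter of compound 3. Going by the values given here, the only steps beyond the scatter are a 2.3-fold lower number from compound 1 to compound 2 (0.37 log units; beyond the scatter), while a 1.4-fold lower number from compound 1 to compound 3 (0.16 log units; within the scatter) stays within it.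

Compound 4 `CCN(CC)CCCNc1nc(-c2ccc(NC(=O)Nc3ccc(C)cc3)cc2)nc2ccsc12` differs from compound 3 by one change: 4-methylphenyl in place of 2-fluorophenyl on an amide-type nitrogen. Among the compounds with values here, no measured step covers a methyl group; the steps that bear on it are those from compound 1 to compound 2 and from compound 2 to compound 3, which show that moving or adding a substituent on this phenyl ring shifts the number by at most a modest amount. On that basis the expected step is a 1.3-fold lower number from compound 3 to compound 4 (0.12 log units; within the scatter), a small movement toward the lower numbers in this assay, likely within the scatter. Compound 4 is therefore estimated at 650 nM in this assay, with a range from 250 nM to 1700 nM.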

Compound 4, half-maximal inhibitory concentration: 1980 nM
For compound 4 the middle estimate is 3.0-fold (0.48 log units) below the measured one, and the stated range ends below it.
By their numbers in this assay, from the lowest: compounds 2, 3, 1 and 4 (each within the scatter of the next, the first and the last beyond it).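

In this assay, for the compounds shown here, methyl in place of fluoro on the same aromatic carbon gives the largest step so far, a 3.7-fold higher number from compound 2 to compound 4 (0.57 log units; beyond the scatter), showing that the identity of the group on this phenyl ring can matter beyond the scatter even when its place on the ring does not change. The exchange of 2-fluorophenyl for 4-methylphenyl on the amide-type nitrogen also goes beyond the scatter, a 2.3-fold higher number from compound 3 to compound 4 (0.36 log units; beyond the scatter), whereas methyl in place of hydrogen stays within it, a 1.6-fold higher number from compound 1 to compound 4 (0.21 log units; within the scatter), so in this assay the 4-methylphenyl group cannot be told apart from the unsubstituted phenyl group, and the lower number seen with 4-fluorophenyl is not shared by methyl. No measurement shown accounts for the difference between fluoro and methyl on this ring.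

The compounds shown leave open whether chloro, methoxy or an amine in place of the methyl would stay with the 4-fluorophenyl compound or with the unsubstituted phenyl compound. They also leave open how the 2-methylphenyl group on the same nitrogen would compare with the 2-fluorophenyl group of compound 3.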